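Three Level Antagonists and a Fourth Still to Be Measured

The source may report more compounds than this note shows. Statements on the series, on what has been measured and on what is new or still open speak of the compounds shown alone.

Of the compounds shown here, three sharing one core have been measured in a functional assay on the whole organism for antagonist activity, with Rattus norvegicus as the target; a lower number here means that less compound is needed, a higher number that more compound is needed for the effect. Compound 1 `Clc1cccc2c1CC2CCCN1CCN(c2cccc3c2OCCO3)CC1` gives 0.63 mg/kg in this assay. Compound 2 `C1=C(CCN2CCN(c3cccc4c3OCCO4)CC2)c2ccccc2C1` gives 0.63 mg/kg, and compound 3 `c1ccc2c(c1)CCC2CN1CCN(c2cccc3c2OCCO3)CC1` gives 0.63 mg/kg. On these numbers compound 1 stands level with compound 2 and with compound 3 at the digits shown; the differences to both lie within the scatter of the measurement, so no order among the three can be read from them.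

The next compound follows on from compound 1. Compound 4 `c1ccc2c(c1)CCC2CCCN1CCN(c2cccc3c2OCCO3)CC1` differs from compound 1 by a group of 9 heavy atoms (9 carbon; one five-membered non-aromatic ring of carbon only, one six-membered aromatic ring of carbon only) in place of a group of 9 heavy atoms (8 carbon, 1 chlorine; one four-membered non-aromatic ring of carbon only, one six-membered aromatic ring of carbon only), on a saturated chain carbon, three bonds along the chain from an amine nitrogen in a ring. The entering 2,3-dihydro-1H-inden-1-yl group already appears in compound 3, there on a shorter chain, and compound 3 sits at the same reading as compound 1.

Because compound 3 gives 0.63 mg/kg and compound 2 gives 0.63 mg/kg, both at the reading of compound 1, compound 4 is expected to change little: the step of no change at the digits printed from compound 1 to compound 4 (within the scatter) is estimated to stay within the scatter, in no particular direction. Compound 4 is therefore expected to give about 0.63 mg/kg in this assay, with a likely range from 0.3 mg/kg to 1.3 mg/kg.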

Compound 4, minimum effective dose: 0.16 mg/kg
The estimate for compound 4 lay 3.9-fold (0.60 log units) above the measured number; measured number outside the range, below it.
By their numbers in this assay, from the lowest: compound 4; then compounds 1, 2 and 3 (each within the scatter of the next).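

In this assay, going by these compounds alone, putting 2,3-dihydro-1H-inden-1-yl in place of the group with chlorine and a four-membered non-aromatic ring, on a saturated chain carbon, three bonds along the chain from an amine nitrogen in a ring, gives a 3.9-fold lower number from compound 1 to compound 4 (0.60 log units; beyond the scatter), the only step in this set that lies beyond the scatter. The earlier compounds shown here stood level and gave no sign that this assay could separate members, whereas this exchange moves the reading even though both groups count 9 heavy atoms. The entering group does not set the reading by itself: on a shorter chain, compound 3 gives 0.63 mg/kg, while on the chain of compound 1, compound 4 gives 0.16 mg/kg.

The exchange alters the chlorine and the ring size together, so the compounds shown cannot assign the step to either, and they leave open how a chlorine on the 2,3-dihydro-1H-inden-1-yl group or a longer chain would read. Nothing given here bears on why the number is lower for compound 4.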